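Swapping a cyano for a methoxy on the para-substituted ring

A few compounds are considered here, and "the series" means these few. Any claim that something is new, unique, unknown or untested is made for them only; others in the source may bear on it.

Measured so far:
- compound 1, `CC/C(=C(/c1ccc(/C=C/C(=O)O)cc1)c1cc2ccccc2[nH]1)c1ccccc1C(F)(F)F`: 8 nM
- compound 2, `CC/C(=C(/c1ccc(/C=C/C(=O)O)cc1)c1cc2ccccc2[nH]1)c1ccc(C#N)cc1`: 278 nM

Going by the values given here, in a functional assay on MCF7 cells (Homo sapiens) for inhibition (on this read-out higher numbers stand for weaker inhibition and lower numbers for stronger inhibition), compound 2 stands at the highest of the two numbers seen, and its only neighbour is compound 1, which lies a long way off: a 35-fold higher number from compound 1 to compound 2 (1.54 log units; beyond the scatter). Compound 3, `CC/C(=C(/c1ccc(/C=C/C(=O)O)cc1)c1cc2ccccc2[nH]1)c1ccc(OC)cc1`, keeps the shared core of compound 2 and differs from it in one place: methoxy in place of cyano on an aromatic carbon, on an aromatic carbon of a six-membered aromatic ring of carbon only, para to a large group. Among the compounds with values here, the one measured step, from compound 1 to compound 2, is of a different kind: it moves a group from one side of the ring to another and changes its identity at the same time, so it speaks only loosely for the change at hand. Within the data shown here, no measured pair shows what a methoxy does in this position. The step from compound 2 to compound 3 in this assay is therefore expected to be modest and of uncertain direction, a 1.9-fold lower number from compound 2 to compound 3 (0.27 log units; within the scatter), with a wide range. Compound 3 is estimated at 150 nM in this assay, between 30 nM and 700 nM.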

Compound 3, half-maximal inhibitory concentration: 61 nM
For compound 3 the middle estimate is 2.5-fold (0.39 log units) above the measured one; low and high end bracket the measured number.
By their numbers in this assay, from the lowest: compound 1; then compound 3; then compound 2.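

In this assay, replacing cyano with methoxy on the same aromatic carbon produces a clear change (a 4.6-fold lower number from compound 2 to compound 3 (0.66 log units; beyond the scatter)). This position therefore responds to the identity of the group, even though the two groups match in heavy atoms, hydrogen-bond donors and acceptors, and net charge. The 4-methoxyphenyl group still does not match the 2-(trifluoromethyl)phenyl group (a 7.6-fold higher number from compound 1 to compound 3 (0.88 log units; beyond the scatter)), so this change closes only part of the gap left by the 4-cyanophenyl group. Nothing measured here gives a reason for the difference between methoxy and cyano.

Between compound 1 and the other two compounds, the group and its place on the ring change together, so it remains open whether a methoxy group would fare better in the place the trifluoromethyl group occupies, or a trifluoromethyl group in the place methoxy occupies. Going by these compounds, it is also open how a hydroxyl group or an amine on this aromatic carbon would compare with methoxy and cyano.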